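The source may hold more compounds than are shown below. What is called first, only, known or untested is meant among the compounds shown, and "the series" means these compounds.

Measured so far in a functional assay on QGY-7703 cells (Homo sapiens) for cytotoxicity, read by MTT assay, with a stated time of 24 h; a lower number here means a stronger inhibitor, a higher number a weaker inhibitor:
compound 1 `CN1C/C(=C\c2cccnc2)C(=O)/C(=C/c2cc([N+](=O)[O-])ccc2F)C1` gives 11100 nM
compound 2 `CN1C/C(=C\c2ccncc2)C(=O)/C(=C/c2ccccc2F)C1` gives 4900 nM

Compound 2 holds the lower of the two numbers, and the gap to compound 1 lies beyond the scatter. Compound 3 `CN1C/C(=C\c2ccncc2)C(=O)/C(=C/c2cc([N+](=O)[O-])ccc2F)C1` is compound 2 with nitro in place of hydrogen on an aromatic carbon, para to a fluoro group (nitro in place of hydrogen on an aromatic carbon). For the measured compounds named here, compound 1 also carries a nitro and gives 11100 nM as its value, but no measured pair isolates that change. A modest rise in this assay is therefore expected, with a 1.4-fold higher number from compound 2 to compound 3 (0.15 log units; within the scatter) as the estimated step. For compound 3 the estimate is 7000 nM with an expected range of 2500 nM to 18000 nM as its bounds.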

Compound 3, half-maximal inhibitory concentration: 5700 nM
Estimate against measurement, compound 3: 1.2-fold (0.09 log units) above, within the range that was stated.
By their numbers in this assay, from the lowest: compounds 2, 3 and 1 (each within the scatter of the next, the first and the last beyond it).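

In this assay, nitro in place of hydrogen on an aromatic carbon, para to a fluoro group, gives a small step (a 1.2-fold higher number from compound 2 to compound 3 (0.07 log units; within the scatter)), so this position accepts nitro with no change beyond the scatter. Pyridin-4-yl in place of pyridin-3-yl, with the nitro kept, also stays within the scatter (a 1.9-fold lower number from compound 1 to compound 3 (0.29 log units; within the scatter)). No measurement bearing on the cause of either step is at hand. As far as these compounds go, whether an amine or a carboxylic acid on the same aromatic carbon would match nitro remains open.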